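Cyano in place of fluoro: compound 3 to compound 4

A few compounds are considered here, and "the series" means these few. Any claim that something is new, unique, unknown or untested is made for them only; others in the source may bear on it.

In a functional assay on MCF7 cells (Homo sapiens) for inhibition, read by MTT assay (a lower number here means a stronger inhibitor of growth, a higher number a weaker inhibitor of growth), compound 1 `COc1cc2oc(-c3cccc(NC(=O)c4cccc(Br)c4)c3)cc(=O)c2c(OC)c1OC` gives 6340 nM, compound 2 `COc1cc2oc(-c3cccc(NC(=O)c4ccccc4Br)c3)cc(=O)c2c(OC)c1OC` gives 55000 nM and compound 3 `COc1cc2oc(-c3cccc(NC(=O)c4ccc(F)cc4)c3)cc(=O)c2c(OC)c1OC` gives 14700 nM. Compound 3 thus holds the middle of the three numbers, nearer to compound 1 than to compound 2.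

Compound 4 `COc1cc2oc(-c3cccc(NC(=O)c4ccc(C#N)cc4)c3)cc(=O)c2c(OC)c1OC` carries cyano in place of fluoro on an aromatic carbon, para to a large group: cyano in place of fluoro on an aromatic carbon.

The measured steps that bear on this all exchange the aryl group on the carbonyl. They are a 2.3-fold higher number from compound 1 to compound 3 (0.37 log units; beyond the scatter), a 3.7-fold lower number from compound 2 to compound 3 (0.57 log units; beyond the scatter) and an 8.7-fold higher number from compound 1 to compound 2 (0.94 log units; beyond the scatter), all modest. Among the measured compounds shown here, the largest of these involves the 2-bromophenyl group of compound 2, which has no counterpart in the present change. For the measured compounds named here, no measured compound carries cyano, so there is no direct precedent. Only a small step with no firm direction is therefore expected in this assay, within the scatter: the estimated change is a 1.1-fold lower number from compound 3 to compound 4 (0.05 log units; within the scatter). For compound 4 the estimated value is 13000 nM, with an expected range of 6000 nM to 30000 nM.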

Compound 4, concentration for 50% growth inhibition: 12700 nM
For compound 4 the middle estimate is 1.0-fold (0.01 log units) above the measured one; the range from low to high includes it.
By their numbers in this assay, from the lowest: compounds 1, 4 and 3 (each within the scatter of the next, the first and the last beyond it); then compound 2.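

In this assay, the exchange of fluoro for cyano para to a large group gives a 1.2-fold lower number from compound 3 to compound 4 (0.06 log units; within the scatter), so the two groups cannot be told apart here despite the added heavy atom and hydrogen-bond acceptor of cyano. The 4-cyanophenyl group also leaves compound 4 clearly separated from the 2-bromophenyl amide, with a 4.3-fold lower number from compound 2 to compound 4 (0.64 log units; beyond the scatter), whereas a 2.0-fold higher number from compound 1 to compound 4 (0.30 log units; within the scatter) places it within the scatter of the 3-bromophenyl amide, a closeness that the 4-fluorophenyl amide compound 3 does not share. Nothing available explains why fluoro and cyano read alike at this position.

On these data alone, whether this holds for an amine, a carboxylic acid or a longer chain at the same position stays open. Also open, as far as these compounds go, is whether 2-cyanophenyl and 3-cyanophenyl groups would separate as the two bromophenyl groups do, with an 8.7-fold higher number from compound 1 to compound 2 (0.94 log units; beyond the scatter).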